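Adding Bromo to the Benzoyl of Compound 2

The compounds below may be only part of what the source reports. "The series", "measured", "known", "first", "only" and "open" are said of these compounds alone.

Compound 1 `CNc1cc(C)c2cc(NC(=O)c3ccc(Cl)c(Cl)c3)ccc2n1`: 2520 nM
Compound 2 `CCN1CCN(c2cc(C)c3cc(NC(=O)c4ccccc4)ccc3n2)CC1`: 14200 nM
Compound 3 `Cc1cc(NCCN(C)C)nc2ccc(NC(=O)c3ccc(Cl)c(Cl)c3)cc12`: 2550 nM

In a functional assay on MCF7 cells (Homo sapiens) for antiproliferative activity, read by MTT assay, with a stated time of 72 h (a higher number here means a weaker inhibitor, a lower number a stronger inhibitor), compound 2 gives the highest of the three numbers, beyond the scatter from both compound 1 and compound 3. Compound 4 `CCN1CCN(c2cc(C)c3cc(NC(=O)c4cccc(Br)c4)ccc3n2)CC1` differs from compound 2 by bromo in place of hydrogen on an aromatic carbon. Among the compounds with values here, no measured step bears directly on this change: the only one, a 1.0-fold higher number from compound 1 to compound 3 (0.01 log units; within the scatter), alters the amine side chain and lies within the scatter. Compound 1 and compound 3, which carry halogens on the benzoyl, show lower numbers than compound 2, but they also differ elsewhere, so this is at most a hint. A modest step down, a 2.0-fold lower number from compound 2 to compound 4 (0.31 log units; beyond the scatter), is expected. Compound 4 is estimated at 7000 nM, ranging from 2500 nM to 20000 nM.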

Compound 4, half-maximal inhibitory concentration: 11600 nM
Compound 4: middle estimate off by 1.7-fold (0.22 log units), on the low side; measured number inside the range.
By their numbers in this assay, from the lowest: compounds 1 and 3 (each within the scatter of the next); then compounds 4 and 2 (each within the scatter of the next).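

Bromo in place of hydrogen on an aromatic carbon of the benzoyl, meta to a large group, gives a 1.2-fold lower number from compound 2 to compound 4 (0.09 log units; within the scatter) in this assay and so stays within the scatter. Within the data shown here, this is the first direct reading of a change on this ring, and at this carbon a single bromine atom does not separate compound 4 from compound 2. No measurement shown offers an explanation for this result. The compounds shown leave open whether an amine or a carboxylic acid on the same aromatic carbon would give a step beyond the scatter.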